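This account rests on a few compounds, and the source may have more. Where it says the series, first, only, none or still open, it means among the compounds named here.

Measured in a functional assay on HCC1806 cells (Homo sapiens) for inhibition, read by sulforhodamine B assay, tested at 10 uM; a lower number here means less inhibition, a higher number more inhibition at the concentration tested (going by the name of the read-out):
- compound 1 `CN1CCN(c2ccc(C3=NN(S(C)(=O)=O)C(c4ccc(N(C)C)cc4)C3)cc2)CC1`: -18.5%
- compound 2 `CN1CCN(c2ccc(C3=NN(S(=O)(=O)C4CC4)C(c4ccc(N(C)C)cc4)C3)cc2)CC1`: 4.7%
- compound 3 `CN1CCN(c2ccc(C3=NN(S(=O)(=O)c4ccc(Br)cc4)C(c4ccc(N(C)C)cc4)C3)cc2)CC1`: 87.1%

Compound 3 stands highest of the three numbers in this assay. Its nearest neighbour is compound 2, separated by a number 82.4 percentage points higher from compound 2 to compound 3 (beyond the scatter), and the furthest is compound 1, separated by a number 105.6 percentage points higher from compound 1 to compound 3 (beyond the scatter). The remaining measured step, a number 23.2 percentage points higher from compound 1 to compound 2 (beyond the scatter), is the only modest one among the three.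

Compound 4 `CN1CCN(c2ccc(C3=NN(S(=O)(=O)c4ccc(C(F)(F)F)cc4)C(c4ccc(N(C)C)cc4)C3)cc2)CC1` differs from compound 3 in a single place: trifluoromethyl in place of bromo on an aromatic carbon. Going by the values given here, every measured step exchanges the entire group on the sulfonyl sulfur, methyl against cyclopropyl or against 4-bromophenyl; no measured step alters a group on the aromatic ring that carries the bromo, so none of them bears directly on this change. What the measured compounds do show is that compound 3, the only one with a 4-bromophenyl on the sulfonyl sulfur, reaches 87.1%, far beyond compound 1 and compound 2. Since compound 4 keeps a substituted phenyl in that position, the step of a number 7.1 percentage points lower from compound 3 to compound 4 (within the scatter) is expected to be small, most likely within the scatter. Compound 4 is therefore estimated at 80% in this assay, with a range from 55% to 100%.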

Compound 4, a percentage reported as inhibition, at one concentration (the size of the read-out at that concentration, not a potency): 27%
For compound 4 the middle estimate is 53 percentage points above the measured one; measured number below the stated range.
By their numbers in this assay, from the lowest: compound 1; then compound 2; then compound 4; then compound 3.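

In this assay the group on the aromatic ring proves to matter in its own right: with the phenyl on the sulfonyl sulfur kept, the read-out is a number 60.1 percentage points lower from compound 3 to compound 4 (beyond the scatter), a change that the earlier exchanges of the whole sulfonyl substituent could not reveal. A substituted phenyl in that position is therefore not enough by itself to give a high number, for 4-(trifluoromethyl)phenyl gives a reading a number 22.3 percentage points higher from compound 2 to compound 4 (beyond the scatter) when set against cyclopropyl and a number 45.5 percentage points higher from compound 1 to compound 4 (beyond the scatter) when set against methyl, and both gains stay well short of what 4-bromophenyl gives. Nothing available here accounts for the wide gap between the bromo and trifluoromethyl compounds.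

On these data alone, whether another group in the same place, such as chloro, methoxy or an amine, would stay near the bromo compound or fall towards the trifluoromethyl one remains open. Also open, as far as these compounds go, is whether this gap would hold at other concentrations, since each number is a single reading at one concentration and not a potency.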